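Swapping the triazole aldehyde for a methyl group

The compounds below may be only part of what the source reports. "The series", "measured", "known", "first", "only" and "open" are said of these compounds alone.

Compound 1 `O=Cc1cn(C[C@H]2CN(c3ccc(C4=CCS(=O)(=O)CC4)c(F)c3)C(=O)O2)nn1` gives 3200 nM in an assay for binding affinity to Amine oxidase [flavin-containing] A (Homo sapiens); a lower number here means a stronger inhibitor, a higher number a weaker inhibitor. Compound 2 `O=C1O[C@@H](Cn2cc(Cl)nn2)CN1c1ccc(C2=CCS(=O)(=O)CC2)c(F)c1` gives 3000 nM in this assay. Compound 3 `CCc1cn(C[C@H]2CN(c3ccc(C4=CCS(=O)(=O)CC4)c(F)c3)C(=O)O2)nn1` reaches only > 200000 nM, which is a limit of the assay rather than a number (the limit of > 200000 nM in this assay, at which 1 of the 3 values shown sits).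

Of the two numbers, compound 1 has the highest, though the step of a 1.1-fold lower number from compound 1 to compound 2 (0.03 log units; within the scatter) stays within the scatter. Compound 4 `Cc1cnnn1C[C@H]1CN(c2ccc(C3=CCS(=O)(=O)CC3)c(F)c2)C(=O)O1` differs from compound 1 by 5-methyl-1H-1,2,3-triazol-1-yl in place of 4-formyl-1H-1,2,3-triazol-1-yl on a saturated chain carbon bound to a saturated ring carbon. The step that bears on this is an at least 62-fold higher number from compound 1 to compound 3 (1.79 log units; beyond the scatter), matched by an at least 66-fold higher number from compound 2 to compound 3 (1.82 log units; beyond the scatter): an alkyl group in place of formyl or chloro cost a great deal. A methyl is alkyl as well, so a large rise, a 31-fold higher number from compound 1 to compound 4 (1.49 log units; beyond the scatter), is expected. Compound 4 is estimated at 100000 nM, in the range 15000 nM to 300000 nM.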

Compound 4, inhibition constant: 4500 nM
For compound 4 the middle estimate is 22-fold (1.35 log units) above the measured one; measured number below the stated range.
By their numbers in this assay, from the lowest: compounds 2, 1 and 4 (each within the scatter of the next). At a limit, above all of these: compound 3.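

An alkyl group on the triazole does not by itself cost binding: the 5-methyl group of compound 4 performs on a par with the formyl group (a 1.4-fold higher number from compound 1 to compound 4 (0.15 log units; within the scatter)) and the chloro group (a 1.5-fold higher number from compound 2 to compound 4 (0.18 log units; within the scatter)). The large gap is confined to the ethyl compound (an at least 44-fold lower number from compound 3 to compound 4 (1.64 log units; beyond the scatter)). The value of compound 3 is a limit, not a number: the limit of > 200000 nM in this assay, at which 1 of the 4 values shown sits.

Going by these compounds, whether that gap follows the ethyl group or its place on the triazole stays open. So does what 4-methyl-1H-1,2,3-triazol-1-yl or 5-ethyl-1H-1,2,3-triazol-1-yl would give.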